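The source may report more compounds than this note shows. Statements on the series, on what has been measured and on what is new or still open speak of the compounds shown alone.

Among the measured compounds shown here, compound 2 `Cc1noc(-c2c(F)cccc2-c2ccc([C@@H](C)Nc3nccc(Cl)c3NC(=O)CC#N)cc2)n1` has the lowest number of the two compounds measured so far in an assay on CHO cells for displacement of a labelled ligand from B1 bradykinin receptor (Homo sapiens) (on this read-out higher numbers stand for weaker inhibition and lower numbers for stronger inhibition), where compound 2 gives 0.5 nM. For the measured compounds named here, its nearest neighbour is compound 1 `C[C@@H](Nc1nccc(Cl)c1NC(=O)CC#N)c1ccc(-c2cccc(F)c2C#N)cc1`, which in this assay gives 2 nM; the only step seen in this set is a 4.0-fold lower number from compound 1 to compound 2 (0.60 log units; beyond the scatter). Compound 3 `C[C@@H](Nc1nccc(Cl)c1NC(=O)CC#N)c1ccc(-c2cccc(F)c2-c2nnn(C)n2)cc1` takes this one step further: 2-methyl-2H-tetrazol-5-yl in place of 3-methyl-1,2,4-oxadiazol-5-yl on an aromatic carbon. Going by the values given here, no measured pair compares two such five-membered aromatic rings with each other, so the step from compound 1 to compound 2 bears on it only by showing that a five-membered aromatic ring at this position is tolerated, and its size gives no direct guide. Compound 3 is therefore expected to stay close to compound 2, with a step of a 1.4-fold higher number from compound 2 to compound 3 (0.15 log units; within the scatter) that should lie within the scatter. The estimate for compound 3 in this assay is 0.7 nM, within a range from 0.25 nM to 2 nM.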

Compound 3, inhibition constant: 0.5 nM
Estimate against measurement, compound 3: 1.4-fold (0.15 log units) above; low and high end bracket the measured number.
By their numbers in this assay, from the lowest: compounds 2 and 3 (each within the scatter of the next); then compound 1.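

In this assay, the 2-methyl-2H-tetrazol-5-yl in place of the 3-methyl-1,2,4-oxadiazol-5-yl gives no change at the digits printed from compound 2 to compound 3 (within the scatter) and so shows that this position, ortho to a fluoro group, accepts a second five-membered aromatic ring with a different number of hetero atoms. The lower number relative to the nitrile is therefore not tied to one ring: the new ring gives a 4.0-fold lower number from compound 1 to compound 3 (0.60 log units; beyond the scatter) and the earlier one gave a 4.0-fold lower number from compound 1 to compound 2 (0.60 log units; beyond the scatter) with the same size of step. Nothing measured on these compounds accounts for the two rings reading alike.

Going by these compounds, whether the methyl group on either ring matters remains open, as does whether an unsubstituted tetrazole would read the same. On these data alone, it is also open how a carboxylic acid or a primary amide, with no five-membered ring at all, would read at this position.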